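The source may hold more compounds than are shown below. What is called first, only, known or untested is meant among the compounds shown, and "the series" means these compounds.

Compound 1 `CC(=O)N1N=C(c2ccccc2)CC1c1ccc(N(C)C)cc1` was tested in a functional assay on IMR-32 cells (Homo sapiens) for cytotoxicity, read by sulforhodamine B assay, with a stated time of 48 h (on this read-out lower numbers stand for stronger inhibition and higher numbers for weaker inhibition), where compound 1 gives 9660 nM. Two other compounds frame that number. For the measured compounds named here, compound 2 `CC(=O)N1N=C(c2cccc([N+](=O)[O-])c2)CC1c1ccccc1` gives 7890 nM in this assay, a value that sits within the scatter of the one for compound 1, so the two cannot be told apart. Compound 3 `CC(=O)N1N=C(c2ccco2)CC1c1ccccc1[N+](=O)[O-]` gives 27900 nM in this assay, and its gap from compound 1 lies beyond the scatter. Among the three numbers, then, compound 1 stands second highest, close to compound 2 and well apart from compound 3.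

The unmeasured compound 4 `CC(=O)N1N=C(c2ccco2)CC1c1ccc(N(C)C)cc1` is reached from compound 1 by a single change: furan-2-yl in place of phenyl on a carbon with a double bond to nitrogen. Going by the values given here, compound 3 also carries a furan-2-yl group in that same place, but it differs from compound 1 in its other ring too, so its value shows only that a furan-bearing analogue can reach a clearly higher number; no measured pair isolates the change itself. The expectation is therefore cautious: a modest move toward a higher number in this assay, of a size that may well stay within the scatter. On that basis compound 4 is expected to give 15000 nM, with a likely range from 6000 nM to 40000 nM. The step from compound 1 to compound 4 that this estimate means is a 1.6-fold higher number from compound 1 to compound 4 (0.19 log units; within the scatter), an expected value rather than a measured one.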

Compound 4, half-maximal inhibitory concentration: 16100 nM
Beside the measured number, compound 4's estimate is 1.1-fold (0.03 log units) below it; the range from low to high includes it.
By their numbers in this assay, from the lowest: compounds 2, 1, 4 and 3 (each within the scatter of the next, the first and the last beyond it).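

In this assay, for the compounds shown here, furan-2-yl in place of phenyl on the carbon with a double bond to nitrogen gives a 1.7-fold higher number from compound 1 to compound 4 (0.22 log units; within the scatter), so this single change, isolated here for the first time, does not separate the two compounds. It also places the furan-bearing compound 4 at 16100 nM and the furan-bearing compound 3 at 27900 nM, values within the scatter of each other, although the two compounds differ in their other ring. Nothing offered here bears on a cause for this result.

The compounds shown leave open whether this position accepts groups further from phenyl and furan-2-yl, such as thiophen-2-yl, a saturated cyclohexyl ring or a ring carrying a carboxylic acid. They also leave open whether the same swap gives a comparably small step when the group of 9 heavy atoms on the other ring atom is replaced, for instance by a phenyl ring bearing a methoxy group or a primary amine.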